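Swapping 3-methylphenyl for naphthalen-2-yl at a stability limit

A few compounds are considered here, and "the series" means these few. Any claim that something is new, unique, unknown or untested is made for them only; others in the source may bear on it.

In an ADME assay on microsomes from liver (Homo sapiens) for metabolic stability, read by LC-MS, with NADPH named in the record, with a stated time of 60 min, tested at 1 uM, in the absence of a further agent (on this read-out higher numbers stand for a more stable compound and lower numbers for a less stable compound), compound 1 `COc1ccc(-c2c(C)nc3c(N4CC[C@@H](NC(=O)COc5ccccc5)C4)cc(C)nn23)cc1OC` gives > 95%, which is a limit and not a number. Compound 2 `COc1ccc(-c2c(C)nc3c(N4CC[C@@H](NC(=O)Nc5ccccc5)C4)cc(C)nn23)cc1OC` gives > 95%, also a limit. Compound 3 `COc1ccc(-c2c(C)nc3c(N4CC[C@@H](NC(=O)Oc5cccc(C)c5)C4)cc(C)nn23)cc1OC` gives > 95%, again only a limit, so its true position is not known. Taken together, the series reads as the limit of > 95% in this assay, at which 3 of the 3 values shown sit.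

Compound 4 `COc1ccc(-c2c(C)nc3c(N4CC[C@@H](NC(=O)Oc5ccc6ccccc6c5)C4)cc(C)nn23)cc1OC` differs from compound 3 by one change: naphthalen-2-yl in place of 3-methylphenyl on an oxygen next to a carbonyl group. In words, naphthalen-2-yl stands in place of 3-methylphenyl on an oxygen next to a carbonyl group.

For the measured compounds named here, two measured steps bear on this change: a step that the two limits leave unreadable from compound 1 to compound 3 and a step that the two limits leave unreadable from compound 2 to compound 3. Neither has a readable size, so the expectation rests mainly on compound 3, whose > 95% is a limit. No step beyond the scatter is expected in this assay, and any shift would be expected to run downward. The estimated step is a number at least 3 percentage points lower from compound 3 to compound 4 (that floor lies within the scatter). Compound 4 is expected at 92%, with an estimated range from 72% to 100%.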

Compound 4, percent of the compound remaining: > 95%
Compound 4: no number, only a limit; the forecaster's own chance of this, stated with the estimate: 50%; at least 3 percentage points between middle value and limit.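

In this assay compound 4 gives > 95%, which is again a limit. For the compounds shown here, no step to compound 4 from compound 1, compound 2 or compound 3 can be read. The compounds shown leave open whether their true stabilities differ at all, and whether naphthalen-2-yl changes anything relative to 3-methylphenyl: the limit of > 95% in this assay, at which 4 of the 4 values shown sit.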